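Amide heteroaryl swap carried from one core to the other

The compounds below may be only part of what the source reports. "The series", "measured", "known", "first", "only" and "open" are said of these compounds alone.

Compound 1 `COc1cc(N(C)C)c(NC(=O)c2ccncn2)cc1Nc1nccc(-c2cn(C)c3ccccc23)n1` and compound 2 `COc1cc(N(C)C)c(NC(=O)c2nccn2C)cc1Nc1nccc(-c2cn(C)c3ccccc23)n1` share one core; compound 3 `COc1cc(N(C)CCN(C)C)c(NC(=O)c2ccncn2)cc1Nc1nc(-c2cn(C)c3ccccc23)c2cccnc2n1` and compound 4 `COc1cc(N(C)CCN(C)C)c(NC(=O)c2nccn2C)cc1Nc1nc(-c2cn(C)c3ccccc23)c2cccnc2n1` share another. The difference between the two cores is not broken down here. In a functional assay on A549 cells (Homo sapiens) for antiproliferative activity, read by MTT assay, with a stated time of 72 h (a lower number here means a stronger inhibitor, a higher number a weaker inhibitor), compound 1 gives 5160 nM and compound 2 gives 10200 nM. The change between them, (1-methyl-1H-imidazol-2-yl in place of pyrimidin-4-yl on a carbonyl carbon), produced a 2.0-fold higher number from compound 1 to compound 2 (0.30 log units; within the scatter). Compound 3 gives 4520 nM in this assay, which lies within the scatter of the number for compound 1.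

Compound 4 is not yet measured. It arises from compound 3 by 1-methyl-1H-imidazol-2-yl in place of pyrimidin-4-yl on a carbonyl carbon, the same change as from compound 1 to compound 2, made at the same place on the carbonyl carbon bound to the amide-type nitrogen. For the measured compounds named here, with the single earlier instance as the only guide, the step from compound 3 to compound 4 in this assay is expected to be of similar size, estimated at a 2.0-fold higher number from compound 3 to compound 4 (0.30 log units; within the scatter), because the earlier swap gave a 2.0-fold higher number from compound 1 to compound 2 (0.30 log units; within the scatter). That earlier step sat at the edge of the scatter, so a step anywhere from no change to somewhat more than that would not be surprising; no second instance is available to narrow it.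

For compound 4 the expected value in this assay is 9000 nM, with a plausible range from 4500 nM to 18000 nM.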

Compound 4, half-maximal inhibitory concentration: 5640 nM
Compound 4: middle estimate off by 1.6-fold (0.20 log units), on the high side, and the stated range covers the measured number.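

In this assay, placing 1-methyl-1H-imidazol-2-yl where pyrimidin-4-yl stood on the carbonyl carbon gives a 1.2-fold higher number from compound 3 to compound 4 (0.10 log units; within the scatter), so the two values on this core cannot be told apart. Set beside the same change on the core of compound 1, the two steps do not differ beyond what repeated measurement allows: the same change on two cores in this assay, a 2.0-fold higher number (0.30 log units; within the scatter) from compound 1 to compound 2 and a 1.2-fold higher number (0.10 log units; within the scatter) from compound 3 to compound 4, 1.6-fold (0.20 log units) apart, within the scatter of two such steps

Within these two pairs, the swap carries from one core to the other without a step beyond the scatter in either case; it does not show that the change has a real effect of any particular size, and with both steps this small and only two pairs in hand, neither a shared effect nor a core-dependent one can be established.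

Still open, as far as these compounds go, is whether other groups on the same carbonyl carbon, such as a plain phenyl ring or a small alkyl like methyl, would give a step beyond the scatter on either core. Also open, from the compounds shown here alone, is how the differences between the two cores contribute on their own, including the dimethylamino group of compound 1 and the longer diamine chain of compound 3, since these compounds differ in more than one place.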